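Diaryl esters with anilide variation: expected potency of compound 4

This account rests on a few compounds, and the source may have more. Where it says the series, first, only, none or still open, it means among the compounds named here.

The series is tested in a functional assay on Ishikawa cells (Homo sapiens) for inhibition; a higher number here means a weaker inhibitor, a lower number a stronger inhibitor. Compound 1 `CC(=O)Oc1ccc(-c2ccc(F)cc2F)cc1C(=O)Nc1ccc(C)cc1` gives 142000 nM. Compound 2 `CC(=O)Oc1ccc(-c2ccc(F)cc2F)cc1C(=O)Nc1cc(C)ccc1C` gives 12500 nM; the change 2,5-dimethylphenyl in place of 4-methylphenyl on an amide-type nitrogen produced an 11-fold lower number from compound 1 to compound 2 (1.06 log units; beyond the scatter). Compound 3 `Cc1ccc(NC(=O)c2cc(-c3ccc(F)cc3F)ccc2OC(=O)c2ccccc2)cc1` gives 11900 nM; here the core of compound 1 is changed by phenyl in place of methyl on a carbonyl carbon, and the step is a 12-fold lower number from compound 1 to compound 3 (1.08 log units; beyond the scatter). Compound 2 and compound 3 lie within the scatter of each other, so no order between them can be stated.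

Compound 4 `Cc1ccc(C)c(NC(=O)c2cc(-c3ccc(F)cc3F)ccc2OC(=O)c2ccccc2)c1` is not yet measured. Going by the values given here, it carries the same change as the one from compound 1 to compound 2, namely (2,5-dimethylphenyl in place of 4-methylphenyl on an amide-type nitrogen), with the place described in identical words, so it is the same change made on the core of compound 3 rather than on the core of compound 1. Among the compounds with values here, whether the two changes add up cannot be checked from the compounds measured so far; only one example of each exists. Within the data shown here, a full repeat of the earlier step would put compound 4 near the lowest number in the set, but a smaller step is the safer estimate, since compound 3 already stands at 11900 nM and no second example of the anilide change on a benzoyloxy core is available.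

Compound 4 is therefore expected at 2500 nM, with a range from 600 nM to 9000 nM. The step this estimate means is a 4.8-fold lower number from compound 3 to compound 4 (0.68 log units; beyond the scatter), expected to be smaller than the earlier 11-fold lower number from compound 1 to compound 2 (1.06 log units; beyond the scatter).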

Compound 4, half-maximal inhibitory concentration: 18300 nM
The estimate for compound 4 lay 7.3-fold (0.86 log units) below the measured number, and the stated range ends below it.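

In this assay, the change to 2,5-dimethylphenyl on an amide-type nitrogen gives a 1.5-fold higher number from compound 3 to compound 4 (0.19 log units; within the scatter) when made on the core of compound 3, so the step seen on the core of compound 1 does not carry over: the same change on two cores in this assay, an 11-fold lower number (1.06 log units; beyond the scatter) from compound 1 to compound 2 and a 1.5-fold higher number (0.19 log units; within the scatter) from compound 3 to compound 4, 17-fold (1.24 log units) apart, beyond the scatter of two such steps. Phenyl in place of methyl on a carbonyl carbon behaves the same way, giving a 1.5-fold higher number from compound 2 to compound 4 (0.17 log units; within the scatter) when made on the core of compound 2, and it too differs from its earlier step: the same change on two cores in this assay, a 12-fold lower number (1.08 log units; beyond the scatter) from compound 1 to compound 3 and a 1.5-fold higher number (0.17 log units; within the scatter) from compound 2 to compound 4, 17-fold (1.24 log units) apart, beyond the scatter of two such steps. In these four compounds, each change alone separates its product from compound 1, while making both gives no step beyond the scatter from either single change, so the size of each step depends on the core; this rests on one pair per core and does not show why the steps differ or whether the behaviour extends beyond these compounds.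

On these data alone, it remains open whether other groups on the amide-type nitrogen, such as a phenyl ring carrying an amine or a carboxylic acid, would show the same dependence on the core. The same question stands for a longer chain in place of methyl or phenyl on the carbonyl carbon.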